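Opening a Sulfone Ring on an Amide Side Chain

The source may hold more compounds than are shown below. What is called first, only, known or untested is meant among the compounds shown, and "the series" means these compounds.

Compound 1, `O=C(NCCSc1nonc1/C(=N/O)Nc1ccc(F)c(C(F)F)c1)C1CS(=O)(=O)C1`: 70 nM
Compound 2, `C[C@@H](CSc1nonc1/C(=N/O)Nc1ccc(F)c(Br)c1)NC(=O)CS(N)(=O)=O`: 93 nM
Compound 3, `CSc1nonc1/C(=N/O)Nc1ccc(F)c(Br)c1`: 560 nM

All three compounds were tested in an assay for inhibition of Indoleamine 2,3-dioxygenase 1 (Homo sapiens), read by fluorescence, with a stated time of 1 h; a higher number here means a weaker inhibitor, a lower number a stronger inhibitor. Compound 1 has the lowest of the three numbers, yet compound 2 sits within the usual scatter of it, so the two cannot be told apart on these data. Compound 3 stands well beyond the scatter, with a clearly higher number, so it is the weakest of the three.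

Compound 4 is `CS(=O)(=O)CC(=O)NCCSc1nonc1/C(=N/O)Nc1ccc(F)c(C(F)F)c1` and has not yet been measured. It differs from compound 1 in one place: a group of 5 heavy atoms (2 carbon, 2 oxygen, 1 sulfur; no ring) in place of a group of 6 heavy atoms (3 carbon, 2 oxygen, 1 sulfur; one four-membered non-aromatic ring with 1 hetero atom), on a carbonyl carbon. In words, a group of 5 heavy atoms (2 carbon, 2 oxygen, 1 sulfur; no ring) takes the place of a group of 6 heavy atoms (3 carbon, 2 oxygen, 1 sulfur; one four-membered non-aromatic ring with 1 hetero atom), on a carbonyl carbon.

Among the compounds with values here, no measured pair shows this exact change, so the expectation rests on the broader picture. Compound 2 carries a different sulfur-bearing amide group and still gives 93 nM in this assay, within scatter of compound 1, which suggests the amide end tolerates variation. The step from compound 1 to compound 4 is therefore expected to be a 1.2-fold higher number from compound 1 to compound 4 (0.08 log units; within the scatter), not beyond the scatter in either direction. Compound 4 is estimated at 85 nM, with a range from 35 nM to 210 nM.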

Compound 4, half-maximal inhibitory concentration: 100 nM
Estimate against measurement, compound 4: 1.2-fold (0.07 log units) below; the range from low to high includes it.
By their numbers in this assay, from the lowest: compounds 1, 2 and 4 (each within the scatter of the next); then compound 3.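

Within the data shown here, on the carbonyl carbon, replacing the group with the four-membered ring by the open (methylsulfonyl)methyl group gives the first direct comparison at this position (a 1.4-fold higher number from compound 1 to compound 4 (0.15 log units; within the scatter)) in this assay. The rest of the molecule stays the same, so this step isolates the change, and it shows that the ring can be opened at this position without a change that stands out from the scatter; earlier, the link between the amide end and the number could only be inferred from compounds differing in more than one place. No supporting measurement bears on this result, so why the two groups read alike stays unknown.

The compounds shown contain sulfur in this amide group in every case where the group is present, so it remains open whether a group without sulfur, such as a simple methyl, an amine or a carboxylic acid, would read the same here. Also open, going by these compounds, is whether a longer chain between the carbonyl and the sulfonyl would be tolerated in the same way, or whether the number would then move beyond the scatter.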